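A few compounds are considered here, and "the series" means these few. Any claim that something is new, unique, unknown or untested is made for them only; others in the source may bear on it.

Compound 1 `Nc1nc(NCc2ccccc2)nc(-c2ccccc2CO)n1` gives 4.35.
Compound 2 `CCNc1nc(NCc2ccccc2)nc(-c2ccccc2CO)n1` gives 4.63.
Compound 3 `Cc1ccccc1-c1nc(N)nc(NCc2ccccc2)n1` gives "not active" (no number reported), with no number.

All three share one core and were tested in a functional assay on cells for positive allosteric modulation of G-protein coupled receptor 68 (Homo sapiens), read by a luciferase reporter and cAMP accumulation, with a stated time of 30 min, at pH 6.8 and pH 8.3, in the presence of a further agent that is not named here; a higher number here means a more potent compound, by a factor of ten per unit of this negative logarithm, a lower number a less potent compound. Going by the values given here, compound 1 gives 4.35 and compound 2 gives 4.63; the only step between measured compounds, a number 0.28 log units higher from compound 1 to compound 2 (within the scatter), lies within the scatter. Compound 3 is reported as "not active" (no number reported) in this assay, with no number, so it stands apart from the other two. Compound 4 `CC(O)c1ccccc1-c1nc(N)nc(NCc2ccccc2)n1` differs from compound 3 by 1-hydroxyethyl in place of methyl on an aromatic carbon. Among the compounds with values here, no measured step bears directly on this change; the single step of a number 0.28 log units higher from compound 1 to compound 2 (within the scatter) concerns another position. Where compound 3 carries methyl, a hydroxymethyl group stands in compound 1, and compound 1 does give 4.35, so a return to a measurable value in this assay is expected. Compound 4 is estimated at 4.4, ranging from 3.8 to 5.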

Compound 4, negative logarithm of the antagonist equilibrium constant: "not active" (no number reported)
Nothing numeric was reported for compound 4, so the estimate cannot be set against anything.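

In this assay compound 3 and compound 4 both stand as not active without a number, so no step can be read between them, and nothing measured here explains this result. The compounds shown leave open whether 1-hydroxyethyl and methyl differ at all in potency.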